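This account rests on a few compounds, and the source may have more. Where it says the series, first, only, none or still open, it means among the compounds named here.

The measured compounds, each with its result in a functional assay, with a stated time of 20 min, tested at 10 uM; a higher number here means a stronger effect of the compound at the concentration tested, a lower number a weaker effect:

compound 1, `COc1cc(/C=C/C(=O)C2=C(/C=C/c3ccc(O)c(OC)c3)NC(=O)NC2c2ccccc2)ccc1O`, gives 26.4% in this assay
compound 2, `COc1cc(/C=C/C(=O)C2=C(/C=C/c3ccc(O)c(OC)c3)NC(=O)NC2c2ccc(C)cc2)ccc1O`, gives 29.9% in this assay
compound 3, `COc1cc(/C=C/C(=O)C2=C(/C=C/c3ccc(O)c(OC)c3)NC(=S)NC2c2ccccc2)ccc1O`, gives 26.5% in this assay

Compound 1 and compound 2 share one core and differ in a single place: methyl in place of hydrogen on an aromatic carbon. This change made a step of a number 3.5 percentage points higher from compound 1 to compound 2 (within the scatter), so the two results cannot be told apart with confidence. Compound 3 carries a different core; how its core differs from that of compound 1 is not broken down here. Its result in this assay sits close to those of compound 1 and compound 2, and all three numbers lie within the scatter of one another.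

Compound 4, `COc1cc(/C=C/C(=O)C2=C(/C=C/c3ccc(O)c(OC)c3)NC(=S)NC2c2ccc(C)cc2)ccc1O`, has not yet been measured. It stands to compound 3 as compound 2 stands to compound 1: methyl in place of hydrogen on an aromatic carbon. The place of the new group is described in the same words for both pairs, so this is the same change, made on the core of compound 3 instead of the core of compound 1.

Going by the values given here, since the only time this change was measured it made a step of a number 3.5 percentage points higher from compound 1 to compound 2 (within the scatter), compound 4 is expected to show a step of about a number 3 percentage points higher from compound 3 to compound 4 (within the scatter) in this assay, a shift that would again fall inside the usual scatter. On that basis compound 4 is estimated to give 29.5% in this assay, most likely between 18% and 41%. This rests on a single earlier example, so the expectation is loose.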

Compound 4, a percentage reported as activity, at one concentration (the size of the read-out at that concentration, not a potency): 43.2%
Compound 4: middle estimate off by 13.7 percentage points, on the low side; the measured number lies above the stated range.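

Replacing phenyl with 4-methylphenyl on the core of compound 3 produces a clear change in this assay, a step of a number 16.7 percentage points higher from compound 3 to compound 4 (beyond the scatter), so on this core the added methyl goes with a stronger effect at the concentration tested. Set beside the same change on the core of compound 1, the two steps point the same way, and the distance between them is no larger than two such steps can show by chance: the same change on two cores in this assay, a number 3.5 percentage points higher (within the scatter) from compound 1 to compound 2 and a number 16.7 percentage points higher (beyond the scatter) from compound 3 to compound 4, 13.2 percentage points apart, within the scatter of two such steps The result therefore does not show that the methyl does more on one core than on the other, and it does not prove that the change carries over with the same size either, since each core offers only one pair and the earlier step cannot be told from scatter.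

The compounds shown hold only hydrogen or methyl at this place, so it remains open how a chlorine atom, a longer chain such as ethyl, or an amine would behave there on either core. Going by these compounds, it also remains open whether the step from adding methyl would be repeated on a further core, or how large it would be there.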